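Methyl for methylamino on the thiophen-2-yl compound

A few compounds are considered here, and "the series" means these few. Any claim that something is new, unique, unknown or untested is made for them only; others in the source may bear on it.

In a functional assay on K562 cells (Homo sapiens), read by MTT assay, with a stated time of 72 h (on this read-out lower numbers stand for stronger inhibition and higher numbers for weaker inhibition), compound 1 (`CNc1ncnc2c1c(-c1cccs1)cn2[C@@H]1O[C@H](CO)[C@@H](O)[C@H]1O`) gives > 20000 nM as a limit and not as a number. In this assay compound 2 (`C#Cc1cn([C@@H]2O[C@H](CO)[C@@H](O)[C@H]2O)c2ncnc(NC)c12`) gives 1380 nM as a measured number. Going by the values given here, the one measured step (an at least 14-fold lower number from compound 1 to compound 2 (1.16 log units; beyond the scatter)) is large but concerns ethynyl in place of thiophen-2-yl, a different group. Compound 3 (`Cc1ncnc2c1c(-c1cccs1)cn2[C@@H]1O[C@H](CO)[C@@H](O)[C@H]1O`) keeps thiophen-2-yl and has methyl in place of methylamino on an aromatic carbon. Among the compounds with values here, no measured step covers this change, and compound 1 sits at a limit, so only a lower number could register. A sizeable step to a lower number is expected (an at least 13-fold lower number from compound 1 to compound 3 (1.12 log units; beyond the scatter)) with wide uncertainty. Compound 3 is estimated at 1500 nM (expected range 150 nM to 15000 nM) in this assay for now.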

Compound 3, half-maximal inhibitory concentration: > 20000 nM
Compound 3 was reported as a limit; the forecaster's own chance of this, stated with the estimate: 20%; middle value at least 13-fold (1.12 log units) from the limit.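

Compound 1 and compound 3 both stand at a limit and not at a number in this assay, so no step between them can be read: the limit of > 20000 nM in this assay, at which 2 of the 3 values shown sit.

From the compounds shown here alone, whether methyl in place of methylamino on an aromatic carbon changes the number at all remains open.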